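From nitrophenyl to methylphenyl: working notes

The source may report more compounds than this note shows. Statements on the series, on what has been measured and on what is new or still open speak of the compounds shown alone.

Values in a physicochemical assay for lipophilicity; on this read-out higher numbers stand for higher lipophilicity and lower numbers for lower lipophilicity:
- compound 1 `C[C@H]1CC[C@@H]2[C@@H](OC(=O)[C@]23CC(c2ccccc2[N+](=O)[O-])=NO3)[C@]2(C)C(=O)C=C[C@@]12O`: 1.37
- compound 2 `C[C@H]1CC[C@@H]2[C@@H](OC(=O)[C@]23CC(c2ccc([N+](=O)[O-])cc2)=NO3)[C@]2(C)C(=O)C=C[C@@]12O`: 1.37
- compound 3 `Cc1ccccc1C1=NO[C@]2(C1)C(=O)O[C@@H]1[C@H]2CC[C@H](C)[C@]2(O)C=CC(=O)[C@@]12C`: 1.86

Compound 1 stands level with compound 2, and together they hold the lowest of the three numbers. Compound 4 `Cc1cccc(C2=NO[C@]3(C2)C(=O)O[C@@H]2[C@H]3CC[C@H](C)[C@]3(O)C=CC(=O)[C@@]23C)c1` differs from compound 1 by 3-methylphenyl in place of 2-nitrophenyl on a carbon with a double bond to nitrogen: 3-methylphenyl in place of 2-nitrophenyl. The closest evidence is a number 0.49 log units higher from compound 1 to compound 3 (beyond the scatter), with methyl in place of nitro on an aromatic carbon, matched by a number 0.49 log units higher from compound 2 to compound 3 (beyond the scatter). Changing 2-nitrophenyl to 4-nitrophenyl gave no change at the digits printed from compound 1 to compound 2 (within the scatter). Going by the values given here, no 3-methylphenyl compound has been measured yet. A modest upward step of similar size is therefore expected in this assay, estimated as a number 0.48 log units higher from compound 1 to compound 4 (beyond the scatter). Compound 4 is expected at 1.85, within an estimated range of 1.55 to 2.15.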

Compound 4, partition coefficient: 1.86
Beside the measured number, compound 4's estimate is 0.01 log units below it; low and high end bracket the measured number.
By their numbers in this assay, from the lowest: compounds 1 and 2 (each within the scatter of the next); then compounds 3 and 4 (each within the scatter of the next).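

In this assay the swap of 2-methylphenyl for 3-methylphenyl gives no change at the digits printed from compound 3 to compound 4 (within the scatter) at this carbon, so the two methylphenyl compounds read alike, as the two nitrophenyl compounds did. The gap to the nitrophenyl compounds also holds for the second methylphenyl group, with a number 0.49 log units higher from compound 1 to compound 4 (beyond the scatter) and a number 0.49 log units higher from compound 2 to compound 4 (beyond the scatter) at the same modest size. No measured evidence on what lies behind this gap is at hand.

Still open, on these data alone, is whether 4-methylphenyl, or a phenyl group carrying an amine or a carboxylic acid, would fall with either pair or apart from both.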